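Replacing the indolyl arm of compound 2 with vinylphenyl

The source may hold more compounds than are shown below. What is called first, only, known or untested is meant among the compounds shown, and "the series" means these compounds.

Three compounds share a core and differ only in the aryl group on the five-membered ring. Compound 1 `COc1ccc(-c2cc3nccc(-c4cc(OC)c(OC)c(OC)c4)n3n2)cc1N` gives 251 nM in a functional assay on HCT-116 cells (Homo sapiens) for inhibition, read by CCK-8 assay, with a stated time of 48 h; a higher number here means a weaker inhibitor, a lower number a stronger inhibitor. Compound 2 `COc1cc(-c2ccnc3cc(-c4ccc5cc[nH]c5c4)nn23)cc(OC)c1OC` gives 187 nM in this assay, the lowest number of the three, yet the step of a 1.3-fold lower number from compound 1 to compound 2 (0.13 log units; within the scatter) stays within the scatter, so compounds 1 and 2 cannot be ranked. Compound 3 `COc1cc(-c2ccnc3cc(-c4ccc(C(C)=O)cc4)nn23)cc(OC)c1OC` gives 4390 nM in this assay; the step of a 17-fold higher number from compound 1 to compound 3 (1.24 log units; beyond the scatter) and the step of a 23-fold higher number from compound 2 to compound 3 (1.37 log units; beyond the scatter) both lie well beyond the scatter.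

Compound 4 `C=Cc1ccc(-c2cc3nccc(-c4cc(OC)c(OC)c(OC)c4)n3n2)cc1` is not yet measured in this assay. Its change from compound 2 is 4-vinylphenyl in place of 1H-indol-6-yl on an aromatic carbon. Among the compounds with values here, the one measured step that bears on it is the move from compound 2 to compound 3, where another six-membered carbon-only ring without a hydrogen-bond donor replaced 1H-indol-6-yl and the number rose by a 23-fold higher number from compound 2 to compound 3 (1.37 log units; beyond the scatter). Within the data shown here, the 4-vinylphenyl group, like 4-acetylphenyl, carries no hydrogen-bond donor, so a rise in the number is expected for compound 4, though with no measured compound carrying a vinyl group the size is uncertain. Compound 4 is estimated at 1500 nM in this assay, within 400 nM to 6000 nM, an expected step of an 8.0-fold higher number from compound 2 to compound 4 (0.90 log units; beyond the scatter).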

Compound 4, half-maximal inhibitory concentration: 1060 nM
Beside the measured number, compound 4's estimate is 1.4-fold (0.15 log units) above it, and the stated range covers the measured number.
By their numbers in this assay, from the lowest: compounds 2 and 1 (each within the scatter of the next); then compound 4; then compound 3.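

In this assay, vinyl in place of acetyl gives a 4.1-fold lower number from compound 3 to compound 4 (0.62 log units; beyond the scatter) on an otherwise unchanged compound, so the group carried on the phenyl ring at this position changes the number even when the ring itself stays the same, something compounds 1 to 3 could not show. The 4-vinylphenyl group, with 0 hydrogen-bond donors, still does not match either aryl group of the two lowest compounds, as a 5.7-fold higher number from compound 2 to compound 4 (0.75 log units; beyond the scatter) and a 4.2-fold higher number from compound 1 to compound 4 (0.63 log units; beyond the scatter) both show, and among these four compounds the two groups without a donor sit highest, though compounds 3 and 4 remain apart, so the absence of a donor does not alone fix the number. No measurement here accounts for any of these steps.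

Going by these compounds, whether vinyl itself matters, or any small carbon substituent would serve, remains open, and an ethyl group or a longer chain in its place would test this. On these data alone, whether a donor on the phenyl ring restores a lower number also remains open, and a primary amine or a hydroxyl group there would address it.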